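From 3-aminophenyl to 2,4-dichlorophenyl

This account rests on a few compounds, and the source may have more. Where it says the series, first, only, none or still open, it means among the compounds named here.

In a functional assay on MCF7 cells (Homo sapiens) for antiproliferative activity, read by MTT assay, with a stated time of 72 h (a higher number here means a weaker inhibitor, a lower number a stronger inhibitor), compound 3 `COc1cc(-n2cnc3ccc(-c4cccc(N)c4)cc32)cc(OC)c1OC` gives 180 nM. Its nearest neighbour, compound 2 `COc1cc(-n2cnc3ccc(-c4cccc(O)c4)cc32)cc(OC)c1OC`, gives 350 nM, and the gap, a 1.9-fold lower number from compound 2 to compound 3 (0.29 log units; within the scatter), leaves the two level. Compound 1 `COc1cc(-n2cnc3ccc(-c4ccccc4Cl)cc32)cc(OC)c1OC` is reported only as a limit, > 10000 nM.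

Compound 4 `COc1cc(-n2cnc3ccc(-c4ccc(Cl)cc4Cl)cc32)cc(OC)c1OC` has not yet been measured. It carries 2,4-dichlorophenyl in place of 3-aminophenyl on an aromatic carbon.

Within the data shown here, two measured steps bear on this change. They are an at least 28-fold lower number from compound 1 to compound 2 (1.45 log units; beyond the scatter) and an at least 55-fold lower number from compound 1 to compound 3 (1.74 log units; beyond the scatter), and both are large. The second comes closest, since it replaces 2-chlorophenyl with the same 3-aminophenyl that compound 4 gives up. Compound 4 keeps a chlorine-bearing phenyl like that of compound 1, so the change is expected to run largely in reverse of an at least 55-fold lower number from compound 1 to compound 3 (1.74 log units; beyond the scatter). The expected step is a 50-fold higher number from compound 3 to compound 4 (1.70 log units; beyond the scatter), toward a weaker inhibitor. For compound 4 the estimated value is 9000 nM, with an expected range from 2000 nM to 30000 nM.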

Compound 4, half-maximal inhibitory concentration: 5420 nM
Beside the measured number, compound 4's estimate is 1.7-fold (0.22 log units) above it, and the stated range covers the measured number.
By their numbers in this assay, from the lowest: compounds 3 and 2 (each within the scatter of the next); then compound 4. At a limit, above all of these: compound 1.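

In this assay, among these compounds, 2,4-dichlorophenyl gives the first exact number for a chlorine-bearing phenyl at this place, with a 30-fold higher number from compound 3 to compound 4 (1.48 log units; beyond the scatter) and a 15-fold higher number from compound 2 to compound 4 (1.19 log units; beyond the scatter), so the large gap to the 3-aminophenyl and 3-hydroxyphenyl compounds no longer rests on a limit alone. Among the compounds shown, the two lowest numbers belong to those two groups, and no compound goes against this. Compound 1 is known only as a limit, so an at least 1.8-fold lower number from compound 1 to compound 4 (0.26 log units; that floor lies within the scatter) does not settle whether the added chloro changes the number at all: the limit of > 10000 nM in this assay, at which 1 of the 4 values shown sits.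

The compounds shown leave open whether a phenyl carrying a methoxy group, a carboxylic acid or a dimethylamino group in place of the amino would stay close to compound 3 or fall toward compound 4.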